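Fluoro for Chloro on a Quinolone Core: Cytotoxicity Outlook

The source may hold more compounds than are shown below. What is called first, only, known or untested is meant among the compounds shown, and "the series" means these compounds.

Of the compounds shown here, three built on one shared core have been measured in an ADME assay on J774 cells (Mus musculus) for cytotoxicity; a lower number here means that less compound is needed, a higher number that more compound is needed for the effect. Compound 1 `Cc1[nH]c2ccc(Cl)cc2c(=O)c1Br` gives 21700 nM. For compound 2 `Cc1[nH]c2ccc(F)cc2c(=O)c1Br` the assay returns only a limit, > 39100 nM. For compound 3 `CCCCC#Cc1c(C)[nH]c2ccc(Cl)cc2c1=O` the assay likewise returns only a limit, > 36300 nM.

Two single-point changes connect these. The change fluoro in place of chloro on an aromatic carbon gives an at least 1.8-fold higher number from compound 1 to compound 2 (0.25 log units; that floor lies within the scatter); this step is a floor rather than a number because the limit of > 39100 nM in this assay, at which 1 of the 3 values shown sits, caps the second value. The two cores of compound 1 and compound 3 differ by hex-1-yn-1-yl in place of bromo on an aromatic carbon, and that change gives an at least 1.6-fold higher number from compound 1 to compound 3 (0.22 log units; that floor lies within the scatter), again a floor because the limit of > 36300 nM in this assay, at which 1 of the 3 values shown sits, caps the value of compound 3.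

Compound 4 `CCCCC#Cc1c(C)[nH]c2ccc(F)cc2c1=O` has not yet been measured in this assay. It differs from compound 3 by fluoro in place of chloro on an aromatic carbon, and the place of this change reads word for word as the place of the change from compound 1 to compound 2, so it is the same change. That earlier change produced an at least 1.8-fold higher number from compound 1 to compound 2 (0.25 log units; that floor lies within the scatter); beside it, the step from compound 3 to compound 4 is expected to be a step that the limit leaves unreadable from compound 3 to compound 4, an expectation resting on compound 3 already sitting at > 36300 nM and on the earlier change moving the number no lower. Compound 4 is therefore expected to give about 60000 nM in this assay, within a range from 30000 nM to 150000 nM, and most likely to be reported only as a limit.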

Compound 4, half-maximal effective concentration: > 38600 nM
Compound 4: a limit, no number (the forecaster's own chance of this, stated with the estimate: 80%); the middle value does not contradict the limit.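

Compound 4 returns only a limit in this assay, > 38600 nM. Compound 2 and compound 3 are also limits, so the steps from compound 3 and compound 2 to compound 4 cannot be read. The compounds shown leave open whether fluoro in place of chloro changes the number at all when hex-1-yn-1-yl is present, and where the actual values of compound 2, compound 3 and compound 4 lie.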